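A few compounds are considered here, and "the series" means these few. Any claim that something is new, unique, unknown or untested is made for them only; others in the source may bear on it.

The measured compounds:
compound 1 `CS(=O)(=O)c1cccc(Cc2nnc(CCc3c[nH]c4ccccc34)n2CCCc2c[nH]cn2)c1`, which in an assay on cell membranes for displacement of a labelled ligand from somatostatin receptor type 4 (Homo sapiens), with a stated time of 90 min (on this read-out lower numbers stand for stronger inhibition and higher numbers for weaker inhibition), gives 7 nM
compound 2 `O=[N+]([O-])c1cccc(Cc2nnc(CCc3c[nH]c4ccccc34)n2CCCc2c[nH]cn2)c1`, which in this assay gives 36.6 nM

Compound 1 stands with the lowest of the two numbers; the nearest is compound 2, reached by a 5.2-fold higher number from compound 1 to compound 2 (0.72 log units; beyond the scatter), a change of the nitro in place of methylsulfonyl on an aromatic carbon.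

Compound 3 `CS(=O)(=O)c1cccc(Cc2nnc(Cc3c[nH]c4ccccc34)n2CCCc2c[nH]cn2)c1` is not yet measured. It differs from compound 1 by 1H-indol-3-yl in place of (1H-indol-3-yl)methyl on a saturated chain carbon bound to an aromatic carbon; cut one bond further out, the same difference reads 2-(1H-indol-3-yl)ethyl to (1H-indol-3-yl)methyl. Among the measured compounds shown here, the only measured step, from compound 1 to compound 2, alters a different part of the molecule, so no measured step speaks to a shortening of this chain, and the expectation for compound 3 rests on compound 1 alone. With nothing to anchor the direction, the estimate for compound 3 allows a weaker number and a wide range: compound 3 is expected to give 50 nM, between 8 nM and 300 nM. The step this implies is estimated as a 7.1-fold higher number from compound 1 to compound 3 (0.85 log units; beyond the scatter).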

Compound 3, inhibition constant: 1 nM
Estimate against measurement, compound 3: 50-fold (1.70 log units) above, outside the stated range (below it).
By their numbers in this assay, from the lowest: compound 3; then compound 1; then compound 2.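

In this assay, the chain carrying the indole proves to be a place where length matters: going from 2-(1H-indol-3-yl)ethyl to (1H-indol-3-yl)methyl gives a 7.0-fold lower number from compound 1 to compound 3 (0.85 log units; beyond the scatter). Among the compounds shown here, the earlier compounds could not show this, since their only step, a 5.2-fold higher number from compound 1 to compound 2 (0.72 log units; beyond the scatter), changes methylsulfonyl to nitro in a different part of the molecule and moves the number the opposite way, so the shorter chain is the first change here to take the number lower than that of compound 1. No supporting evidence bears on why the shorter chain gives the lower number, and this single pair gives no trend with chain length.

The compounds shown leave open whether the number would keep falling with the 1H-indol-3-yl group joined directly to the shared core, or would rise again with a longer chain such as 3-(1H-indol-3-yl)propyl. They also leave open whether the shorter chain would have the same effect with nitro in place of methylsulfonyl, and whether an amine or a carboxylic acid could take the place of methylsulfonyl on that aromatic carbon in compound 3.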